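Thiophen-2-yl ketone next in the cytotoxicity series

The source may report more compounds than this note shows. Statements on the series, on what has been measured and on what is new or still open speak of the compounds shown alone.

compound 1 `CC(=O)c1ccn(-c2ccc3c(c2)B(O)OC3)c1`: > 10 ug/mL
compound 2 `O=C(c1ccc(O)cc1)c1ccn(-c2ccc3c(c2)B(O)OC3)c1`: > 10 ug/mL

Compound 1 is `CC(=O)c1ccn(-c2ccc3c(c2)B(O)OC3)c1`; in an ADME assay on L929 cells (Mus musculus) for cytotoxicity, read by resazurin assay, with a stated time of 72 h (a lower number here means a stronger inhibitor, a higher number a weaker inhibitor), compound 1 gives > 10 ug/mL, which is a limit of the assay and not a number. Compound 2 is `O=C(c1ccc(O)cc1)c1ccn(-c2ccc3c(c2)B(O)OC3)c1`. In this assay compound 2 gives > 10 ug/mL, again a limit and not a number. The step that the two limits leave unreadable from compound 1 to compound 2 therefore cannot be read, and compound 2 stands at the limit of > 10 ug/mL in this assay, at which 2 of the 2 values shown sit, with no measured number to place it more closely.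

The next compound, compound 3, is `O=C(c1ccn(-c2ccc3c(c2)B(O)OC3)c1)c1cccs1`; the change from compound 2 is thiophen-2-yl in place of 4-hydroxyphenyl on a carbonyl carbon. Going by the values given here, no measured step bears on this change, and the one measured step is unreadable, so the expected step that the limit leaves unreadable from compound 2 to compound 3 rests only on both measured compounds sitting at the limit; no direction beyond the scatter is expected. Compound 3 is expected at about 15 ug/mL, with a range from 6 ug/mL to 40 ug/mL, most likely reported once more only as a limit.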

Compound 3, half-maximal inhibitory concentration: > 10 ug/mL
Compound 3 gave a limit, no number; the forecaster's own chance of this, stated with the estimate: 75%; the middle value is on the limit's open side.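

In this assay no step can be read among compound 1, compound 2 and compound 3, all three reported only as a limit: the limit of > 10 ug/mL in this assay, at which 3 of the 3 values shown sit. The compounds shown leave open how far each lies from that limit, and whether the group on the carbonyl carbon changes cytotoxicity at all.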